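Ester size change in a fatty acid transport protein inhibitor series

The source may hold more compounds than are shown below. What is called first, only, known or untested is meant among the compounds shown, and "the series" means these compounds.

Measured compounds:
- compound 1, `CCn1c(CNc2ccccc2)nnc1SCC(=O)Nc1ccc(C(=O)OC)cc1`: "not determined" (no result reported)
- compound 2, `CCC(=O)c1ccc2oc(CS(=O)(=O)c3nnc(CNc4ccccc4)n3CC)nc2c1`: 11900 nM

The series is followed in an assay on isolated protein for inhibition of long-chain fatty acid transport protein 1 (Mus musculus); on this read-out higher numbers stand for weaker inhibition and lower numbers for stronger inhibition. Compound 1, `CCn1c(CNc2ccccc2)nnc1SCC(=O)Nc1ccc(C(=O)OC)cc1`, carries no single number on this read-out; for compound 1 the result in this assay is "not determined" (no result reported). Within the data shown here, compound 2, `CCC(=O)c1ccc2oc(CS(=O)(=O)c3nnc(CNc4ccccc4)n3CC)nc2c1`, is the only member with a measured value: in this assay compound 2 gives 11900 nM, a weak result. Among the measured compounds shown here, compound 1 and compound 2 differ in several places and no single step connects them, so their two values can only be set side by side, and for compound 1 there is none to set.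

Compound 3, `CCn1c(CNc2ccccc2)nnc1SCC(=O)Nc1ccc(C(=O)OC(C)(C)C)cc1`, is the pending compound. It differs from compound 1 in one place, (tert-butyl in place of methyl on an oxygen next to a carbonyl group). Without a value for compound 1 and without any comparable step elsewhere in the series, the size of this step in this assay cannot be read off; no change beyond the usual scatter is expected in either direction.

The only anchor is the weak value of compound 2 in this assay, 11900 nM. Compound 3 is therefore expected to land at about 12000 nM, within a range from 2500 nM to 60000 nM.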

Compound 3, half-maximal inhibitory concentration: > 10000 nM
Compound 3 gave a limit, no number; the forecaster's own chance of this, stated with the estimate: 40%; the middle value lies beyond the limit too.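

In this assay compound 3 gives > 10000 nM, a limit and not a number. Among these compounds, compound 1 carries no number on this read-out, so no step from compound 1 to compound 3 can be read. The compounds shown leave open whether methoxycarbonyl to tert-butoxycarbonyl changes inhibition at all, and in which direction.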